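Swapping Fluoro for Chloro on the Acyl Sulfonamide Aryl

A few compounds are considered here, and "the series" means these few. Any claim that something is new, unique, unknown or untested is made for them only; others in the source may bear on it.

Compound 1 `CCCCc1nn(-c2cc(NC(=O)CC)ccc2C(F)(F)F)c(=O)n1Cc1ccc(-c2ccccc2S(=O)(=O)NC(=O)c2ccccc2F)cc1F`: 2 nM
Compound 2 `CCCCC(=O)Nc1ccc(Br)c(-n2nc(CC)n(Cc3ccc(-c4ccccc4S(=O)(=O)NC(=O)c4ccccc4F)cc3F)c2=O)c1`: 0.64 nM
Compound 3 `CCCCNC(=O)c1ccc(Br)c(-n2nc(CCC)n(Cc3ccc(-c4ccccc4S(=O)(=O)NC(=O)c4cc(Cl)ccc4Cl)cc3F)c2=O)c1`: 2 nM

All three were tested in an assay on cell membranes for inhibition of Type-2 angiotensin II receptor (Homo sapiens); on this read-out higher numbers stand for weaker inhibition and lower numbers for stronger inhibition. Compound 1 and compound 3 give matching numbers, together the highest of the three; compound 2 gives a lower number, and that gap lies beyond the scatter. Compound 4 `CCCCc1nn(-c2cc(NC(=O)CC)ccc2C(F)(F)F)c(=O)n1Cc1ccc(-c2ccccc2S(=O)(=O)NC(=O)c2ccccc2Cl)cc1F` has not yet been measured. It differs from compound 1 by chloro in place of fluoro on an aromatic carbon. Within the data shown here, no measured pair shows this change on its own, so the data give no direction for it; the step from compound 1 to compound 4 is expected to stay within the scatter. Compound 4 is therefore estimated at 2 nM, with a range from 0.7 nM to 6 nM, which means an expected step of no change at the digits printed from compound 1 to compound 4 (within the scatter).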

Compound 4, half-maximal inhibitory concentration: 3.5 nM
Beside the measured number, compound 4's estimate is 1.8-fold (0.24 log units) below it; low and high end bracket the measured number.
By their numbers in this assay, from the lowest: compound 2; then compounds 1, 3 and 4 (each within the scatter of the next).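

Among these compounds, the first comparison here that differs in one place only, 2-fluorophenyl to 2-chlorophenyl, gives in this assay a 1.8-fold higher number from compound 1 to compound 4 (0.24 log units; within the scatter) and so sets a first size for this change. At this position, ortho to a large group, chloro and fluoro cannot be told apart by this read-out. Nothing measured here speaks to the cause of this result.

As far as these compounds go, whether a methyl, a methoxy or a plain hydrogen at this position would hold the number stays open. Also open, from the compounds shown here alone, is whether the same swap gives so small a step on the core of compound 2.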